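Quinoline carboxamides: chloro to methoxy on the pendant aryl

The source may hold more compounds than are shown below. What is called first, only, known or untested is meant among the compounds shown, and "the series" means these compounds.

Of the compounds shown here, three of this quinoline carboxamide series have been measured in a functional assay on MKN-45 cells (Homo sapiens) for cytotoxicity, read by MTT assay, with a stated time of 72 h; on this read-out lower numbers stand for stronger inhibition and higher numbers for weaker inhibition. Compound 1 `COc1cccc(-c2cc(C(=O)Nc3ccc(Oc4ccnc5cc(OCCCN6CCCCC6)c(OC)cc45)c(F)c3)c3ccccc3n2)c1` gives 360 nM. Compound 2 `COc1cc2c(Oc3ccc(NC(=O)c4cc(-c5cccc(Cl)c5)nc5ccccc45)cc3F)ccnc2cc1OCCCN1CCCCC1` gives 11 nM. Compound 3 `COc1cc2c(Oc3ccc(NC(=O)c4cc(-c5cccc(Cl)c5)nc5ccc(F)cc45)cc3F)ccnc2cc1OCCCN1CCC(C)CC1` gives 10 nM; its number and that of compound 2 lie within the usual scatter of each other, so no order between them is claimed, while both stand well apart from compound 1.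

Compound 2 and compound 1 differ in one place: methoxy in place of chloro on an aromatic carbon. This change produced a 33-fold higher number from compound 2 to compound 1 (1.51 log units; beyond the scatter), a step beyond the scatter. The difference between the cores of compound 2 and compound 3 is not broken down here.

Compound 4 `COc1cccc(-c2cc(C(=O)Nc3ccc(Oc4ccnc5cc(OCCCN6CCC(C)CC6)c(OC)cc45)c(F)c3)c3cc(F)ccc3n2)c1` is not yet measured. It differs from compound 3 in one place: methoxy in place of chloro on an aromatic carbon. This is the same change as from compound 2 to compound 1, and it occurs twice among the compounds shown; the place is described in the same words in both cases. Going by the values given here, the only precedent is the single step from compound 2 to compound 1, so the expectation rests on one pair. For compound 4 in this assay a step of about a 33-fold higher number from compound 3 to compound 4 (1.52 log units; beyond the scatter) is expected, because the same change gave a 33-fold higher number from compound 2 to compound 1 (1.51 log units; beyond the scatter) on the closely related core. Compound 4 is therefore estimated at 330 nM, with a likely range from 120 nM to 900 nM.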

Compound 4, half-maximal inhibitory concentration: 730 nM
Estimate against measurement, compound 4: 2.2-fold (0.34 log units) below, and the stated range covers the measured number.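

In this assay, replacing 3-chlorophenyl with 3-methoxyphenyl a second time gives a 73-fold higher number from compound 3 to compound 4 (1.86 log units; beyond the scatter), in the same direction as the earlier pair and again a large step. Set side by side, the two steps cannot be told apart, so in these compounds the change carries between the two cores as a large rise in the number, with no measurable dependence on the core: the same change on two cores in this assay, a 33-fold higher number (1.51 log units; beyond the scatter) from compound 2 to compound 1 and a 73-fold higher number (1.86 log units; beyond the scatter) from compound 3 to compound 4, 2.2-fold (0.35 log units) apart, within the scatter of two such steps. This rests on two pairs only, and it shows neither why the methoxy compounds give the higher numbers nor that a step of this size would hold on any core beyond these two.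

Only chloro and methoxy are shown on this six-membered aromatic ring of carbon only, so it remains open whether another group at the same place, such as fluoro, methyl, nitrile or an amine, would give numbers nearer those of the chloro compounds or those of the methoxy compounds. Also open, as far as these compounds go, is how each part of the difference between the cores of compound 2 and compound 3 acts on its own, as the two pairs carry those differences together.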